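Demethylation step on the aryl ring in a cytotoxicity series

The source may hold more compounds than are shown below. What is called first, only, known or untested is meant among the compounds shown, and "the series" means these compounds.

Compound 1 `COc1ccc(C2CC(c3cccc4ccccc34)=NN2C(C)=O)cc1OC` and compound 2 `COc1cc(C2CC(c3cccc4ccccc34)=NN2C(C)=O)ccc1O` share one core; compound 3 `COc1ccc(C2CC(c3ccc4ccccc4c3)=NN2CC=O)cc1OC` has a core whose difference from that of compound 1 is not broken down here. In a functional assay on OVCAR cells (Homo sapiens) for cytotoxicity, read by sulforhodamine B assay, with a stated time of 48 h (on this read-out higher numbers stand for weaker inhibition and lower numbers for stronger inhibition), compound 1 gives 2690 nM and compound 2 gives 2730 nM; the change between them, (hydrogen in place of methyl on an oxygen on an aromatic ring), made a 1.0-fold higher number from compound 1 to compound 2 (0.01 log units; within the scatter). In this assay compound 3 gives 2450 nM. Compound 4 `COc1ccc(C2CC(c3ccc4ccccc4c3)=NN2CC=O)cc1O` is not yet measured; it differs from compound 3 by hydrogen in place of methyl on an oxygen on an aromatic ring, the same change as between compound 1 and compound 2, at the same kind of place. Because the earlier step was a 1.0-fold higher number from compound 1 to compound 2 (0.01 log units; within the scatter), compound 4 is expected to stay close to compound 3, with an expected step of a 1.0-fold higher number from compound 3 to compound 4 (0.01 log units; within the scatter). The estimate for compound 4 in this assay is 2500 nM, expected between 1400 nM and 4500 nM.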

Compound 4, half-maximal inhibitory concentration: 2160 nM
Compound 4: middle estimate off by 1.2-fold (0.06 log units), on the high side, and the stated range covers the measured number.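

In this assay, the step of a 1.1-fold lower number from compound 3 to compound 4 (0.05 log units; within the scatter) comes from methoxy to hydroxy on the second core. Set beside the step on the first core, the change carries over without a difference that can be told from the scatter: the same change on two cores in this assay, a 1.0-fold higher number (0.01 log units; within the scatter) from compound 1 to compound 2 and a 1.1-fold lower number (0.05 log units; within the scatter) from compound 3 to compound 4, 1.2-fold (0.06 log units) apart, within the scatter of two such steps

This rests on two pairs in one cell assay, and neither step lies beyond the scatter. It does not show that the change would stay this small on other cores or in other cells, and it gives no cause.

Still open, as far as these compounds go, is how an ethyl group or a longer chain on that oxygen would read. From the compounds shown here alone, an amine in place of the hydroxy is equally open.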